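Stereo-undefined fluoroethyl ether in the triazole series

The source may hold more compounds than are shown below. What is called first, only, known or untested is meant among the compounds shown, and "the series" means these compounds.

Compound 3 `FCCOc1cccc(-c2cn([C@H]3CN4CCC3CC4)nn2)c1` is one of three members of this set measured in an assay on HEK293 cells for displacement of a labelled ligand from Neuronal acetylcholine receptor; alpha3/beta4 (Homo sapiens), read by scintillation counting, with a stated time of 120 min; a lower number here means a stronger inhibitor, a higher number a weaker inhibitor. Compound 3 gives 558 nM, the highest number of the three. Compound 1 `Fc1ccc(COc2cccc(-c3cn(C4CN5CCC4CC5)nn3)c2)cc1` gives 13.9 nM, and compound 2 `c1ccc(COc2cccc(-c3cn(C4CN5CCC4CC5)nn3)c2)cc1` gives 7.57 nM. Within the data shown here, compound 3 thus stands well apart from both: the difference to compound 1 and to compound 2 lies beyond the scatter in each case, while compound 1 and compound 2 lie within the scatter of each other, the step of a 1.8-fold lower number from compound 1 to compound 2 (0.26 log units; within the scatter) being the only one-place step available.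

Compound 4 `FCCOc1cccc(-c2cn(C3CN4CCC3CC4)nn2)c1` is the next member to be measured in this assay. It differs from compound 3 as follows: the two compounds have the same atoms and bonds; at least one stereo element is drawn with a configuration in one of them and without one in the other: 1 of 3 stereo elements differ; a stereocentre at a saturated ring carbon is drawn R in compound 3 and without a configuration in compound 4. Among the measured compounds shown here, no measured pair in this set shows the effect of leaving the configuration at that stereocentre undefined; the one measured step, a 1.8-fold lower number from compound 1 to compound 2 (0.26 log units; within the scatter), concerns a fluoro-for-hydrogen exchange on an aromatic carbon and does not bear on this change. Compound 4 is therefore expected to remain near compound 3, with a step of a 1.2-fold lower number from compound 3 to compound 4 (0.09 log units; within the scatter) that need not exceed the scatter in either direction. Compound 4 is estimated at 450 nM, with a range from 120 nM to 1200 nM.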

Compound 4, inhibition constant: 20.9 nM
Beside the measured number, compound 4's estimate is 22-fold (1.33 log units) above it; measured number outside the range, below it.
By their numbers in this assay, from the lowest: compounds 2, 1 and 4 (each within the scatter of the next, the first and the last beyond it); then compound 3.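

In this assay, the configuration drawn at the saturated ring carbon matters far more than any step seen so far, with a 27-fold lower number from compound 3 to compound 4 (1.43 log units; beyond the scatter) even though the two compounds have the same atoms and bonds. The fluoroethyl ether does not by itself set the number high: with fluoromethyl in place of 4-fluorophenyl on the saturated chain carbon bound to an oxygen on an aromatic ring, the step is a 1.5-fold higher number from compound 1 to compound 4 (0.18 log units; within the scatter), and with fluoromethyl in place of phenyl at that place it is a 2.8-fold higher number from compound 2 to compound 4 (0.44 log units; beyond the scatter), a modest change. The large gap between compound 3 and compound 4 can be tied to only one structural difference: the fact that one of compounds 3 and 4 is drawn with a defined configuration and the other without, at the place where they differ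

Open, from the compounds shown here alone, is how a compound drawn S at that stereocentre would stand, and whether compound 1 and compound 2, also drawn without a configuration there, would show a similar gap if drawn R. Also open is whether the same gap would hold with a longer chain or an amine in place of fluoromethyl on the saturated chain carbon.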